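Swapping furan-3-yl for 1H-pyrrol-2-yl

The source may report more compounds than this note shows. Statements on the series, on what has been measured and on what is new or still open speak of the compounds shown alone.

Going by the values given here, compound 2 `COC(=O)c1nc(-c2ccoc2)n(-c2ccc(F)cc2)n1` holds the only numeric value in a functional assay on NPC-TW01 cells (Homo sapiens) for inhibition, read by MTT assay, with a stated time of 72 h (a lower number here means a stronger inhibitor of growth, a higher number a weaker inhibitor of growth), where compound 2 gives 11700 nM. Compound 1 `CCCCc1nc(C(=O)OC)nn1-c1ccc(F)cc1` sits at a limit of the assay, > 100000 nM (the limit of > 100000 nM in this assay, at which 1 of the 2 values shown sits). Among the compounds with values here, the single measured step, an at least 8.5-fold lower number from compound 1 to compound 2 (0.93 log units; beyond the scatter), is the only guide. Compound 3 `COC(=O)c1nc(-c2ccc[nH]2)n(-c2ccc(F)cc2)n1` differs from compound 2 by 1H-pyrrol-2-yl in place of furan-3-yl on an aromatic carbon. That earlier step replaced a chain with a five-membered aromatic ring, whereas this one exchanges one such ring for another, so a smaller step is expected, probably within the scatter. Compound 3 is therefore estimated at 10000 nM (range 3000 nM to 35000 nM), an expected step of a 1.2-fold lower number from compound 2 to compound 3 (0.07 log units; within the scatter).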

Compound 3, concentration for 50% growth inhibition: 9580 nM
Compound 3: middle estimate off by 1.0-fold (0.02 log units), on the high side; the range from low to high includes it.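

In this assay, the exchange of furan-3-yl for 1H-pyrrol-2-yl at this position trades a hydrogen-bond acceptor for a hydrogen-bond donor, yet the step stays within the scatter: a 1.2-fold lower number from compound 2 to compound 3 (0.09 log units; within the scatter). Replacing butyl with this second five-membered aromatic ring gives a step beyond the scatter: an at least 10-fold lower number from compound 1 to compound 3 (1.01 log units; beyond the scatter). Compound 1 stands at a limit of the assay: the limit of > 100000 nM in this assay, at which 1 of the 3 values shown sits.

From the compounds shown here alone, whether a phenyl ring, an amine or a carboxylic acid on this carbon would give a similar number stays open. The compounds shown also leave open what the methoxycarbonyl and 4-fluorophenyl groups contribute, since both stay fixed throughout.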